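The source may hold more compounds than are shown below. What is called first, only, known or untested is meant among the compounds shown, and "the series" means these compounds.

Measured so far:
Compound 1 `COC(=O)c1c(-c2ccc([N+](=O)[O-])cc2)oc2ccccc2c1=O`: > 25 ug/mL
Compound 2 `O=C(O)c1c(-c2ccc([N+](=O)[O-])cc2)oc2ccccc2c1=O`: > 25 ug/mL

Both entries come from a functional assay on SK-MEL cells (Homo sapiens) for cytotoxicity, read by MTT assay, with a stated time of 6 days (on this read-out higher numbers stand for an effect only at larger amounts of compound and lower numbers for an effect already at smaller amounts), and neither is a number. Compound 2 stands only at a limit, > 25 ug/mL. Compound 1 is likewise reported only as a limit, > 25 ug/mL. The whole record is thus (the limit of > 25 ug/mL in this assay, at which 2 of the 2 values shown sit).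

Compound 3 `COc1ccc2oc(-c3ccc([N+](=O)[O-])cc3)c(C(=O)O)c(=O)c2c1` is compound 2 with one change on the shared core: methoxy in place of hydrogen on an aromatic carbon. It carries methoxy in place of hydrogen on an aromatic carbon.

Among the compounds with values here, the only measured step is a step that the two limits leave unreadable from compound 1 to compound 2. That step concerns a different place in the molecule and gives no size to carry over, so nothing measured bears directly on the new group. No step beyond the usual scatter is therefore expected in this assay, and no direction can be argued. The expectation rests on compound 2, which sits at the limit of > 25 ug/mL, and a further report of a limit is the likeliest outcome.

For compound 3 the estimated value is 30 ug/mL, with an expected range from 12 ug/mL to 60 ug/mL. This estimate means an expected step that the limit leaves unreadable from compound 2 to compound 3.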

Compound 3, concentration for half-maximal effect: > 25 ug/mL
Compound 3: a limit, no number; the forecaster's own chance of this, stated with the estimate: 80%; the middle value is on the limit's open side.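

Compound 3 stands only at the limit > 25 ug/mL in this assay and has no number there. Within the data shown here, compound 2 is also reported only as a limit, so no step between compound 2 and compound 3 can be read. The compounds shown leave open whether any change on the shared core gives a measurable effect, as the whole record remains: the limit of > 25 ug/mL in this assay, at which 3 of the 3 values shown sit.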